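Serine to Leucine on the Benzyl Ester Series

This account rests on a few compounds, and the source may have more. Where it says the series, first, only, none or still open, it means among the compounds named here.

Compound 1 `O=C(CN(c1ncnc2c1ncn2C1CCCCO1)C1CC1)N[C@@H](CO)C(=O)OCc1ccccc1` gives 27.8% in a functional assay on the whole organism (Tail, strain ICR) with Mus musculus as the target, in the tail flick test, with a stated time of 30 min, at a dose of 25 umol/kg by the oral route; a lower number here means a weaker effect, a higher number a stronger effect of the compound at the dose given; this is the second highest of three numbers, within the scatter of compound 3 `CC(C)C[C@H](NC(=O)CN(c1nc(Cl)nc2[nH]cnc12)C1CC1)C(=O)O`, which gives 23.4%. Compound 2 `N=C(N)NCCC[C@H](NC(=O)CN(c1nc(Cl)nc2[nH]cnc12)C1CC1)C(=O)O` gives 45.4%, and compound 1 stands below it by a gap beyond the scatter. Compound 4 `CC(C)C[C@H](NC(=O)CN(c1ncnc2c1ncn2C1CCCCO1)C1CC1)C(=O)OCc1ccccc1` differs from compound 1 by isopropyl in place of hydroxy on a saturated chain carbon, two bonds along the chain from an amide-type nitrogen and a carbonyl carbon. Among the measured compounds shown here, the only measured step at this place, a number 22 percentage points lower from compound 2 to compound 3 (beyond the scatter), starts from a different group and on a different core, so it bears on this change only loosely. Since compound 3, which carries the same isobutyl, stands within the scatter of compound 1, compound 4 is expected to show no step beyond the scatter, a number 2.8 percentage points lower from compound 1 to compound 4 (within the scatter). The estimate for compound 4 is 25%, between 10% and 42%.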

Compound 4, a percentage reported as activity, at one dose (the size of the read-out at that dose, not a potency): 26.2%
The estimate for compound 4 lay 1.2 percentage points below the measured number; the range from low to high includes it.
By their numbers in this assay, from the lowest: compounds 3, 4 and 1 (each within the scatter of the next); then compound 2.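

Exchanging hydroxy for isopropyl at this place, with the core and the benzyl ester unchanged, gives in this assay a number 1.6 percentage points lower from compound 1 to compound 4 (within the scatter). On this core, then, the read-out at the dose given does not separate the two groups, even though the hydroxy's hydrogen-bond donor and acceptor are gone. Nothing available explains this result. As far as these compounds go, it remains open whether a primary amine or a phenyl ring at this place would move the read-out beyond the scatter on this core.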